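The compounds below may be only part of what the source reports. "The series", "measured", "known", "first", "only" and "open" are said of these compounds alone.

For the measured compounds named here, compound 2, `COc1cc(N)c(Cl)cc1C(=O)N[C@H]1CCN(CC2CCN(C(=S)C(C)C)CC2)C[C@H]1OC`, stands second highest of the three numbers measured so far: in an assay on COS-7 cells for displacement of a labelled ligand from 5-hydroxytryptamine receptor 4 (Homo sapiens), read by scintillation counting, with a stated time of 30 min (on this read-out lower numbers stand for stronger inhibition and higher numbers for weaker inhibition), compound 2 gives 155 nM. Compound 3, `COc1cc(N)c(Cl)cc1C(=O)N[C@H]1CCN(CC2CCN(C(=O)CC(C)C)CC2)C[C@H]1OC`, gives 78 nM in this assay, and the step of a 2.0-fold lower number from compound 2 to compound 3 (0.30 log units; within the scatter) stays within the scatter. Compound 1, `COc1cc(N)c(Cl)cc1C(=O)N[C@H]1CCN(CCCn2cncn2)C[C@H]1OC`, gives 1270 nM in this assay, and the step of an 8.2-fold lower number from compound 1 to compound 2 (0.91 log units; beyond the scatter) lies beyond it. Compound 4, `COc1cc(N)c(Cl)cc1C(=O)N[C@H]1CCN(CCCn2cccc2)C[C@H]1OC`, differs from compound 2 in that (a group of 7 heavy atoms (6 carbon, 1 nitrogen; one five-membered aromatic ring with 1 hetero atom) in place of a group of 11 heavy atoms (9 carbon, 1 nitrogen, 1 sulfur; one six-membered non-aromatic ring with 1 hetero atom), on a saturated chain carbon bound to an amine nitrogen in a ring). This change runs opposite to the step of an 8.2-fold lower number from compound 1 to compound 2 (0.91 log units; beyond the scatter), in which a five-membered aromatic ring on a chain gave way to the six-membered ring group; reversing that kind of change is expected to raise the number. For compound 4 the expected step is therefore a 6.5-fold higher number from compound 2 to compound 4 (0.81 log units; beyond the scatter). Compound 4 is estimated at 1000 nM, within a range from 300 nM to 3500 nM.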

Compound 4, half-maximal inhibitory concentration: 648 nM
For compound 4 the middle estimate is 1.5-fold (0.19 log units) above the measured one; the range from low to high includes it.
By their numbers in this assay, from the lowest: compounds 3 and 2 (each within the scatter of the next); then compounds 4 and 1 (each within the scatter of the next).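

Replacing 1H-1,2,4-triazol-1-yl with 1H-pyrrol-1-yl makes no clear difference in this assay, as a 2.0-fold lower number from compound 1 to compound 4 (0.29 log units; within the scatter) shows. Compounds 1 and 4, each with a five-membered aromatic ring, therefore read alike, while a 4.2-fold higher number from compound 2 to compound 4 (0.62 log units; beyond the scatter) shows that compound 4, like compound 1, stands apart from compound 2 with its six-membered non-aromatic ring. Nothing here explains these results.
Still open, from the compounds shown here alone, is whether a phenyl group or an amine in place of 1H-pyrrol-1-yl would read like compound 4 or like compound 2.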